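Series notes: estimating compound 4 from compound 2

A few compounds are considered here, and "the series" means these few. Any claim that something is new, unique, unknown or untested is made for them only; others in the source may bear on it.

Among the measured compounds shown here, compound 2 `Cc1ccc(Cn2cc(COc3ccc4c(=O)ccoc4c3)nn2)cc1` is the only member of this set with a number in a functional assay on A549 cells (Homo sapiens) for cytotoxicity, read by MTT assay, with a stated time of 48 h (a lower number here means a stronger inhibitor, a higher number a weaker inhibitor), where compound 2 gives 50700 nM. Compound 1 `O=c1ccoc2cc(OCc3cn(Cc4ccccc4)nn3)ccc12` reaches only a limit in this assay, > 100000 nM. Compound 3 `O=c1ccoc2cc(OCc3cn(Cc4cccc(F)c4)nn3)ccc12` likewise sits at a limit in this assay, > 100000 nM. The picture is thus framed by the limit of > 100000 nM in this assay, at which 2 of the 3 values shown sit. The unmeasured compound 4 `O=c1ccoc2cc(OCc3cn(Cc4ccccc4Br)nn3)ccc12` differs from compound 2 by 2-bromophenyl in place of 4-methylphenyl on a saturated chain carbon bound to an aromatic nitrogen. For the measured compounds named here, two measured steps bear on this change: an at least 1.9-fold lower number from compound 1 to compound 2 (0.29 log units; that floor lies within the scatter) and an at least 1.9-fold higher number from compound 2 to compound 3 (0.29 log units; that floor lies within the scatter), each read against a limit, so neither shows a shift beyond the scatter; a step that the two limits leave unreadable from compound 1 to compound 3 adds nothing readable. So far, varying the group on the saturated chain carbon bound to an aromatic nitrogen has moved values only between a single number and the limit, and no direction beyond the scatter can be read. For compound 4 the step of a 1.6-fold higher number from compound 2 to compound 4 (0.20 log units; within the scatter) is expected, with a real chance that only a limit is reported. The estimate for compound 4 is 80000 nM, ranging from 25000 nM to 250000 nM.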

Compound 4, half-maximal inhibitory concentration: > 100000 nM
Compound 4 was reported as a limit (the forecaster's own chance of this, stated with the estimate: 55%); at least 1.2-fold (0.09 log units) between middle value and limit.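

In this assay compound 4 gives > 100000 nM, which is a limit and not a number. The change from 4-methylphenyl to 2-bromophenyl on a saturated chain carbon bound to an aromatic nitrogen gives an at least 1.9-fold higher number from compound 2 to compound 4 (0.29 log units; that floor lies within the scatter), so a bromo-bearing group joins the fluoro-bearing group of compound 3 and the plain phenyl of compound 1 at the limit, although no shift beyond the scatter is shown, and the steps that link compound 4 to compound 1 and compound 3 cannot be read. The 4-methylphenyl of compound 2 remains the one exception to the run of limits: the limit of > 100000 nM in this assay, at which 3 of the 4 values shown sit.

As far as these compounds go, how far the three limit compounds really lie from compound 2 stays open, so the exception cannot be sized. Also open, from the compounds shown here alone, is whether a longer chain, or a phenyl carrying an amine or a carboxylic acid, at this place would give a number at all.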